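This account rests on a few compounds, and the source may have more. Where it says the series, first, only, none or still open, it means among the compounds named here.

Measured in a functional assay on HCT-116 cells (Homo sapiens) for cytotoxicity, read by MTT assay, with a stated time of 72 h; a lower number here means a stronger inhibitor, a higher number a weaker inhibitor:

- Compound 1 `O=C(NCc1ccc(F)cc1)c1nc(Br)c2cccnc2c1NCc1ccc(F)cc1`: > 20000 nM, a limit
- Compound 2 `CN(C)CCCNc1c(C(=O)NCc2ccc(F)cc2)nc(Br)c2cccnc12`: > 10000 nM, a limit
- Compound 3 `O=C(NCc1ccc(F)cc1)c1nc(Br)c2cccnc2c1NCCO`: > 20000 nM, a limit

None of the three compounds has a numerical value, only a limit. Compound 3 gives > 20000 nM, which is a limit, and it sits at the limit of > 20000 nM in this assay, at which 2 of the 3 values shown sit. Its position relative to compound 1 and compound 2 therefore cannot be read.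

The next compound, compound 4 `Cc1ccc(S(=O)(=O)Oc2c(C(=O)NCc3ccc(F)cc3)nc(Br)c3cccnc23)cc1`, changes the core of compound 3 at one place: ((4-methylphenyl)sulfonyl)oxy in place of (2-hydroxyethyl)amino on an aromatic carbon, (((4-methylphenyl)sulfonyl)oxy in place of (2-hydroxyethyl)amino on an aromatic carbon). Among the measured compounds shown here, none of the measured compounds carries ((4-methylphenyl)sulfonyl)oxy there, so this change has no measured precedent.

For the measured compounds named here, three measured steps bear on it: a step that the two limits leave unreadable from compound 1 to compound 2, a step that the two limits leave unreadable from compound 1 to compound 3 and a step that the two limits leave unreadable from compound 2 to compound 3. Going by the values given here, none has a readable size, so they offer no size to carry over, and they show only that three different groups at this place all ended in a limit. A limit is thus the likelier report for compound 4 in this assay, and no direction can be firmly expected. The expected change is an at least 1.3-fold lower number from compound 3 to compound 4 (0.12 log units; that floor lies within the scatter), an estimate that carries wide uncertainty. For compound 4 the estimated value is 15000 nM, with an expected range from 4000 nM to 40000 nM.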

Compound 4, half-maximal inhibitory concentration: > 20000 nM
Compound 4 ended at the assay's limit; the forecaster's own chance of this, stated with the estimate: 65%; middle value at least 1.3-fold (0.12 log units) away from the limit.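

In this assay compound 4 gives > 20000 nM, which is a limit. Its steps from compound 1, compound 2 and compound 3 cannot be read, and all four compounds carry only limits. The compounds shown leave open whether any group at this aromatic carbon gives a numerical value in this assay.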